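This account rests on a few compounds, and the source may have more. Where it says the series, first, only, none or still open, it means among the compounds named here.

Measured so far in a functional assay on MCF7 cells (Homo sapiens) for antiproliferative activity, read by MTT assay, with a stated time of 72 h; a higher number here means a weaker inhibitor, a lower number a stronger inhibitor:
compound 1 `CCN1CCN(c2cc(C)c3cc(NC(=O)c4cccc(C)c4)ccc3n2)CC1`, with 7800 nM
compound 2 `Cc1cc(NCCN(C)C)nc2ccc(NC(=O)c3ccc(Cl)c(Cl)c3)cc12`, with 2550 nM

Compound 2 holds the lower of the two numbers; compound 1 sits at a higher number, and that gap lies beyond the usual scatter. Compound 3 `Cc1cc(N2CCN(C(C)C)CC2)nc2ccc(NC(=O)c3ccc(Cl)c(Cl)c3)cc12` differs from compound 2 in one place: 4-isopropylpiperazin-1-yl in place of (2-(dimethylamino)ethyl)amino on an aromatic carbon. Among the compounds with values here, no pair of measured compounds differing in a single place is available, so the size of this step rests on expectation alone. The step of a 1.2-fold higher number from compound 2 to compound 3 (0.07 log units; within the scatter) is expected to be small, not clearly beyond the scatter in either direction. Compound 3 is therefore estimated at 3000 nM, within a range from 1000 nM to 9000 nM.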

Compound 3, half-maximal inhibitory concentration: 1710 nM
For compound 3 the middle estimate is 1.8-fold (0.24 log units) above the measured one; measured number inside the range.
By their numbers in this assay, from the lowest: compounds 3 and 2 (each within the scatter of the next); then compound 1.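

In this assay, putting 4-isopropylpiperazin-1-yl in place of (2-(dimethylamino)ethyl)amino on this aromatic carbon next to the ring nitrogen gives a 1.5-fold lower number from compound 2 to compound 3 (0.17 log units; within the scatter). At this position, then, a chain with 1 hydrogen-bond donor and no ring can give way to a six-membered non-aromatic ring with 0 hydrogen-bond donors without a change beyond the scatter. No measurement at hand accounts for this result. Open, going by these compounds, is whether a morpholin-4-yl group or a longer aminoalkyl chain on the same carbon would also stay within the scatter of compound 2.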